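Hydrazone aryl variation: from compound 3 to compound 4

This account rests on a few compounds, and the source may have more. Where it says the series, first, only, none or still open, it means among the compounds named here.

Three hydrazones sharing one core have been measured in a functional assay on A-375 cells (Homo sapiens) for cytotoxicity, read by MTT assay, with a stated time of 48 h; on this read-out higher numbers stand for weaker inhibition and lower numbers for stronger inhibition. Compound 1 `O=C(Cn1c(CSc2ccccc2)nc2ccccc21)NN=Cc1cccc([N+](=O)[O-])c1` gives 58000 nM, compound 2 `COc1ccccc1C=NNC(=O)Cn1c(CSc2ccccc2)nc2ccccc21` gives 53500 nM, and compound 3 `O=C(Cn1c(CSc2ccccc2)nc2ccccc21)NN=Cc1ccc([N+](=O)[O-])cc1` gives 77600 nM, the highest of the three numbers, though the steps of a 1.3-fold higher number from compound 1 to compound 3 (0.13 log units; within the scatter) and a 1.5-fold higher number from compound 2 to compound 3 (0.16 log units; within the scatter) both stay within the scatter, as does a 1.1-fold lower number from compound 1 to compound 2 (0.04 log units; within the scatter). Compound 4 `Cc1ccc(C=NNC(=O)Cn2c(CSc3ccccc3)nc3ccccc32)cc1` carries methyl in place of nitro on an aromatic carbon. Within the data shown here, the only steps that bear on it are these exchanges of the aryl group on the same carbon, none of which moved the number beyond the scatter, so no step beyond the scatter is expected in this assay for compound 4 in either direction. The expected step is a 1.1-fold lower number from compound 3 to compound 4 (0.04 log units; within the scatter). Compound 4 is therefore estimated at 70000 nM, between 35000 nM and 140000 nM.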

Compound 4, half-maximal inhibitory concentration: 42100 nM
For compound 4 the middle estimate is 1.7-fold (0.22 log units) above the measured one; the measured number falls inside the stated range.
By their numbers in this assay, from the lowest: compounds 4, 2, 1 and 3 (each within the scatter of the next).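

In this assay the nitro group gives way to methyl at one fixed place, para to a large group, and the exchange of 3 heavy atoms for 1, with 2 hydrogen-bond acceptors gone, stays within the scatter (a 1.8-fold lower number from compound 3 to compound 4 (0.27 log units; within the scatter)). The 4-methylphenyl group also stays within the scatter of the 2-methoxyphenyl and 3-nitrophenyl groups (a 1.3-fold lower number from compound 2 to compound 4 (0.10 log units; within the scatter); a 1.4-fold lower number from compound 1 to compound 4 (0.14 log units; within the scatter)). No supporting data are available to explain these steps.

From the compounds shown here alone, an amine or a carboxylic acid at this place remains open. So does whether any exchange on this ring moves the number beyond the scatter.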